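This account rests on a few compounds, and the source may have more. Where it says the series, first, only, none or still open, it means among the compounds named here.

Working notes on the ester series.

Compound 1 `CC1=CC[C@H](C(C)C)c2cc(C)c(OC(=O)c3ccc(C)cc3)cc21` is the reference point here. Within the data shown here, in a functional assay on U-251 cells (Homo sapiens) for antiproliferative activity, read by sulforhodamine B assay, with a stated time of 48 h, tested at 50 uM (on this read-out higher numbers stand for more inhibition at the one concentration tested (going by the name of the read-out) and lower numbers for less inhibition), compound 1 gives 67.7%, the highest of the two numbers obtained in that assay so far. Compound 3 `COc1ccc(C(=O)Oc2cc3c(C)ccc(C(C)C)c3cc2C)cc1`, which carries the 4-methoxyphenyl ester on a different core, gives 42.6% in this assay, a number that lies well below compound 1 and beyond the usual scatter. Compound 2 `Cc1cc2c(C(C)C)ccc(C)c2cc1OC(=O)c1cccc(C(F)(F)F)c1` is reported as "not active" (no number reported) in this assay, with no number given.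

Compound 4 `COc1ccc(C(=O)Oc2cc3c(cc2C)[C@@H](C(C)C)CC=C3C)cc1` has not yet been tested. It keeps the core of compound 1 and differs from it in one place: methoxy in place of methyl on an aromatic carbon. Among the measured compounds shown here, no measured pair in the set isolates this change on the shared core, so the size of the step cannot be read off directly. Given that compound 3 gives 42.6% with the 4-methoxyphenyl ester, though on a different core, a modest drop is expected rather than a gain, with the step from compound 1 to compound 4 estimated at a number 12.7 percentage points lower from compound 1 to compound 4 (beyond the scatter). Compound 4 is accordingly expected to give about 55% in this assay, within a range of 35% to 75%.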

Compound 4, a percentage reported as inhibition, at one concentration (the size of the read-out at that concentration, not a potency): 37%
For compound 4 the middle estimate is 18 percentage points above the measured one; low and high end bracket the measured number.
By their numbers in this assay, from the lowest: compounds 4 and 3 (each within the scatter of the next); then compound 1.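

On the core of compound 1, the change from 4-methylphenyl to 4-methoxyphenyl can now be read in isolation: in this assay it gives a number 30.7 percentage points lower from compound 1 to compound 4 (beyond the scatter), a large step. This position, para to a large group, is therefore not indifferent to the swap of methyl for methoxy, and inhibition at the one concentration tested falls well beyond the scatter. No measurement at hand accounts for the size of this step.

From the compounds shown here alone, with a single replacement read at this position, it remains open whether an amine, a hydroxyl, a chlorine or a longer chain such as ethyl would keep the inhibition of compound 1 or lose it as well. The compounds shown also give no pair for this change on the core of compound 3, so whether the step carries over to that core stays open.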